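A few compounds are considered here, and "the series" means these few. Any claim that something is new, unique, unknown or untested is made for them only; others in the source may bear on it.

The study concerns an assay on isolated protein for inhibition of kallikrein-7 (Homo sapiens), read by fluorescence, with stated times of 10 min and 30 min; a lower number here means a stronger inhibitor, a higher number a weaker inhibitor. Compound 1 `Cc1ccc(S(=O)(=O)n2cc(C3CNC(C4CCCCC4)=N3)c3ccccc32)cc1` reaches only a limit of the assay: in this assay compound 1 gives > 100000 nM, which is the limit of > 100000 nM in this assay, at which 1 of the 3 values shown sits. Compound 2 `CC1=NC(c2cn(S(=O)(=O)c3cccc(Cl)c3)c3ccccc23)CN1` likewise stops at a limit; in this assay compound 2 gives > 30000 nM, which is the limit of > 30000 nM in this assay, at which 1 of the 3 values shown sits. For the measured compounds named here, compound 3 `CC1=NC(c2cn(S(=O)(=O)c3cccc(Cl)c3)c3ccc(C)cc23)CN1` carries a methyl in place of hydrogen on an aromatic carbon of compound 2, and in this assay compound 3 gives 30000 nM, the only actual number among the three values. The step of a number no higher from compound 2 to compound 3 (the limit leaves the size open) is a number no higher, with its size left open by the limit. Compound 4 `CC1=NC(c2cn(S(=O)(=O)c3c(Cl)cccc3Cl)c3ccc(C)cc23)CN1` differs from compound 3 by 2,6-dichlorophenyl in place of 3-chlorophenyl on a sulfonyl sulfur. Going by the values given here, no measured step changes the group on the sulfonyl sulfur alone; compound 1 and compound 2 differ in more than one place and both end at limits. Nothing therefore points to a shift beyond the scatter in this assay. Compound 4 is expected to sit close to compound 3. The expected step is no change at the digits printed from compound 3 to compound 4 (within the scatter). The estimate for compound 4 is 30000 nM, with a range from 8000 nM to 100000 nM.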

Compound 4, half-maximal inhibitory concentration: 14000 nM
Beside the measured number, compound 4's estimate is 2.1-fold (0.33 log units) above it; low and high end bracket the measured number.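

In this assay, for the compounds shown here, the group on the sulfonyl sulfur is the first place where a single change gives a readable step: 2,6-dichlorophenyl in place of 3-chlorophenyl gives a 2.1-fold lower number from compound 3 to compound 4 (0.33 log units; beyond the scatter). The step is modest but beyond the scatter, so the aryl group on this sulfur does affect the number, and a second chlorine on that ring is tolerated. Nothing measured here accounts for the step.

The compounds shown leave open whether a different group on this phenyl ring, such as methoxy, an amine or a carboxylic acid, would move the number further. They also leave open whether 2,6-dichlorophenyl would give a similar step on the core of compound 2, which lacks the methyl group of compound 3.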